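A few compounds are considered here, and "the series" means these few. Any claim that something is new, unique, unknown or untested is made for them only; others in the source may bear on it.

Series on the shared core, varied at the aryl group. Compound 1 `CCC1=C(O)c2c(oc(-c3ccccc3)cc2=O)C(CC)(CC)C1=O` carries a plain phenyl. In a functional assay on KB cells (Homo sapiens) for antiproliferative activity, read by sulforhodamine B assay, with a stated time of 3 days (a higher number here means that more compound is needed for the effect, a lower number that less compound is needed), compound 1 gives only a limit, > 236 uM. Compound 2 `CCC1=C(O)c2c(oc(-c3ccccc3C(F)(F)F)cc2=O)C(CC)(CC)C1=O` gives 45.6 uM in this assay, which is an at least 5.1-fold lower number from compound 1 to compound 2 (0.71 log units; beyond the scatter). Compound 3 `CCC1=C(O)c2c(oc(-c3ccccc3F)cc2=O)C(CC)(CC)C1=O` again gives only a limit in this assay, > 56.2 uM. Compound 3 thus stands as a limit, as does one other value in the set; an at least 1.2-fold higher number from compound 2 to compound 3 (0.09 log units; that floor lies within the scatter), while a step that the two limits leave unreadable from compound 1 to compound 3. Compound 4 `CCC1=C(O)c2c(oc(-c3cc(C)cc(C)c3)cc2=O)C(CC)(CC)C1=O` carries 3,5-dimethylphenyl in place of 2-fluorophenyl on an aromatic carbon. Going by the values given here, no measured step exchanges one aryl substituent pattern for another of this kind; the only readable step, an at least 5.1-fold lower number from compound 1 to compound 2 (0.71 log units; beyond the scatter), gave a lower number when trifluoromethyl replaced hydrogen. Compound 4 is therefore expected to give 60 uM (range 15 uM to 250 uM) in this assay, an expected step that the limit leaves unreadable from compound 3 to compound 4 that may itself remain a limit.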

Compound 4, concentration for half-maximal effect: 45.5 uM
For compound 4 the middle estimate is 1.3-fold (0.12 log units) above the measured one; the range from low to high includes it.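

In this assay, going by these compounds alone, replacing phenyl gives an at least 5.1-fold lower number from compound 1 to compound 4 (0.71 log units; beyond the scatter), so trifluoromethyl is no longer the only change at this position with a step beyond the scatter. Compound 2 gives 45.6 uM and compound 4 gives 45.5 uM, practically the same number from two different aryl groups. Against 2-fluorophenyl the reading is weaker, with an at least 1.2-fold lower number from compound 3 to compound 4 (0.09 log units; that floor lies within the scatter), so it sets no order between these two groups.

Going by these compounds, whether one methyl group alone would carry the step stays open. So does how an aryl group bearing an amine or a carboxylic acid would read.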